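Arylpiperazine urea series: nitrophenyl in place of chlorophenyl

The source may report more compounds than this note shows. Statements on the series, on what has been measured and on what is new or still open speak of the compounds shown alone.

Measured so far:
compound 1 `CCC1=C(C(N)=O)C(c2ccc(F)cc2F)N(C(=O)NCCCN2CCN(c3ccccc3C(N)=O)CC2)C(=O)N1`: 1100 nM
compound 2 `COC(=O)C1=C(C)NC(=O)N(C(=O)NCCCN2CCN(c3ccc(Cl)cc3)CC2)C1c1ccc(F)c(F)c1`: 52 nM

In an assay on liver for binding affinity to Alpha-1D adrenergic receptor (Homo sapiens), using microsomes (on this read-out lower numbers stand for stronger inhibition and higher numbers for weaker inhibition), compound 2 gives 52 nM and holds the lowest number of the two compounds measured. Among the compounds with values here, the only comparison is compound 1, which in this assay gives 1100 nM; the gap between the two values lies well beyond the scatter of repeated measurements, though the two compounds differ in several places at once, so no single change can be read from that pair.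

Compound 3 `COC(=O)C1=C(C)NC(=O)N(C(=O)NCCCN2CCN(c3cccc([N+](=O)[O-])c3)CC2)C1c1ccc(F)c(F)c1` is not yet measured. It differs from compound 2 in one place: 3-nitrophenyl in place of 4-chlorophenyl on an amine nitrogen in a ring. Within the data shown here, no measured pair shows this change, so its size cannot be taken from the data. The remainder of compound 2 is kept unchanged.

The expected step from compound 2 to compound 3 in this assay is a 1.9-fold higher number from compound 2 to compound 3 (0.28 log units; within the scatter), a small weakening that may well fall within the scatter. Compound 3 is therefore estimated at 100 nM, with a range from 25 nM to 400 nM.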

Compound 3, inhibition constant: 340 nM
Compound 3: the middle estimate sits 3.4-fold (0.53 log units) below what was measured, within the range that was stated.
By their numbers in this assay, from the lowest: compound 2; then compound 3; then compound 1.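

In this assay, within the data shown here, the replacement of 4-chlorophenyl by 3-nitrophenyl on an amine nitrogen in a ring gives a 6.5-fold higher number from compound 2 to compound 3 (0.82 log units; beyond the scatter) and is the first reading of this position with the rest of the molecule held constant. Compound 1 and compound 2 differ in several places at once, so that pair could not isolate this group; this step shows that the aryl group here can by itself move the number beyond the scatter, with 4-chlorophenyl the better of the two groups compared on this core. No measurement in hand explains the size or direction of the step.

The step changes both the substituent and its place on the phenyl ring, so the compounds shown cannot separate those two contributions. Still open, on these data alone, is where a plain phenyl, a methoxyphenyl or an aminophenyl would fall relative to compound 2 and compound 3, and whether the same step would hold on the core of compound 1.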